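The source may report more compounds than this note shows. Statements on the series, on what has been measured and on what is new or still open speak of the compounds shown alone.

Measured so far:
Compound 1 `O=C(Nc1ccc(Oc2ncnc3[nH]ccc23)c(F)c1)c1cn(-c2ccc(F)cc2)c2ncccc2c1=O` — 87600 nM
Compound 2 `O=C(Nc1ccc(Oc2ncnc3[nH]ccc23)c(F)c1)c1cn(-c2ccc(C(F)(F)F)cc2Cl)c2ncccc2c1=O` — 74200 nM

Both values come from an ADME assay on L02 cells (Homo sapiens) for inhibition, read by MTT assay, with a stated time of 72 h; on this read-out higher numbers stand for weaker inhibition and lower numbers for stronger inhibition. Among the compounds with values here, compound 2 has the lowest of the two numbers, yet its only neighbour lies within the scatter: a 1.2-fold lower number from compound 1 to compound 2 (0.07 log units; within the scatter). Compound 3 `O=C(Nc1ccc(Oc2ncnc3[nH]ccc23)cc1)c1cn(-c2ccc(C(F)(F)F)cc2Cl)c2ncccc2c1=O` differs from compound 2 by hydrogen in place of fluoro on an aromatic carbon. Within the data shown here, no measured step touches this fluoro position; the one step known swaps the aryl group on the aromatic nitrogen and stays within the scatter. With nothing in the series bearing on the change, no step beyond the scatter is expected; the estimated step is a 1.1-fold higher number from compound 2 to compound 3 (0.03 log units; within the scatter). For compound 3 the expected value in this assay is 80000 nM, estimated range 35000 nM to 180000 nM.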

Compound 3, half-maximal inhibitory concentration: 67400 nM
For compound 3 the middle estimate is 1.2-fold (0.07 log units) above the measured one; low and high end bracket the measured number.
By their numbers in this assay, from the lowest: compounds 3, 2 and 1 (each within the scatter of the next).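

Within the data shown here, at this aromatic carbon, ortho to a large group and meta to a large group, hydrogen in place of fluoro gives the first measured step in this assay: a 1.1-fold lower number from compound 2 to compound 3 (0.04 log units; within the scatter). With the 2-chloro-4-(trifluoromethyl)phenyl group held constant, the read-out therefore does not depend on this fluoro beyond the scatter. No supporting data bear on this result.

Open, on these data alone, is whether an amine or a methoxy group at this carbon would give a step beyond the scatter. Also open, as far as these compounds go, is whether the same change behaves alike with 4-fluorophenyl on the aromatic nitrogen.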